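Shortening the ester chain on compound 3

The compounds below may be only part of what the source reports. "The series", "measured", "known", "first", "only" and "open" are said of these compounds alone.

Values in a functional assay on DU-145 cells (Homo sapiens) for inhibition, read by MTT assay, with a stated time of 24 h; on this read-out higher numbers stand for weaker inhibition and lower numbers for stronger inhibition:
- compound 1 `C/C=C(\C)C(=O)O[C@H]1[C@]2(C)C[C@@H]3O[C@@]1(O)C=C1C4=CC(=O)O[C@@H](c5ccoc5)[C@]4(C)CC[C@@H]1[C@]3(C)[C@@H]2C(=O)C(=O)OC`: > 100000 nM (a limit)
- compound 2 `C/C=C(\C)C(=O)O[C@@H]1[C@]2(OC(=O)CCCC)C=C3C4=CC(=O)O[C@@H](c5ccoc5)[C@]4(C)CC[C@@H]3[C@@]3(C)[C@H](C[C@]1(C)[C@H]3[C@@H](OC(=O)CCCC)C(=O)OC)O2`: 4200 nM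
- compound 3 `C/C=C(\C)C(=O)O[C@@H]1[C@]2(OC(=O)CCCC)C=C3C4=CC(=O)O[C@@H](c5ccoc5)[C@]4(C)CC[C@@H]3[C@@]3(C)[C@H](C[C@]1(C)[C@H]3[C@@H](O)C(=O)OC)O2`: 5200 nM

Compound 3 stands level with compound 2, and the step between them is a 1.2-fold higher number from compound 2 to compound 3 (0.09 log units; within the scatter). Compound 1 gives > 100000 nM, which is a limit and not a number. Within the data shown here, no measured single-place step links compound 1 to the other two.

The next compound is compound 4 `C/C=C(\C)C(=O)O[C@@H]1[C@]2(OC(=O)CC)C=C3C4=CC(=O)O[C@@H](c5ccoc5)[C@]4(C)CC[C@@H]3[C@@]3(C)[C@H](C[C@]1(C)[C@H]3[C@@H](O)C(=O)OC)O2`, which differs from compound 3 by hydrogen in place of ethyl on a saturated chain carbon, two bonds along the chain from a carbonyl carbon. In words, this is hydrogen in place of ethyl on a saturated chain carbon, two bonds along the chain from a carbonyl carbon, so butylcarbonyl becomes propanoyl.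

Among the measured compounds shown here, only one measured step bears on this change. It is the step to compound 3 (a 1.2-fold higher number from compound 2 to compound 3 (0.09 log units; within the scatter)), which puts hydrogen in place of a whole butylcarbonyl on an oxygen on a saturated carbon and stays within the scatter. It lies at a different ester, so it offers only indirect guidance. The smaller change to compound 4 is therefore not expected to move the number beyond the scatter.

The expected step is small (a 1.1-fold higher number from compound 3 to compound 4 (0.02 log units; within the scatter)).

For compound 4 the estimated value is 5500 nM, with an expected range from 2500 nM to 14000 nM.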

Compound 4, half-maximal inhibitory concentration: 6700 nM
Estimate against measurement, compound 4: 1.2-fold (0.09 log units) below; measured number inside the range.
By their numbers in this assay, from the lowest: compounds 2, 3 and 4 (each within the scatter of the next). At a limit, above all of these: compound 1.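

Working notes on the series: the ester that stays in place in compound 3 tolerates a shorter chain in this assay, since taking butylcarbonyl to propanoyl, with hydrogen in place of ethyl on a saturated chain carbon, two bonds along the chain from a carbonyl carbon, gives a step that stays within the scatter (a 1.3-fold higher number from compound 3 to compound 4 (0.11 log units; within the scatter)). Among these compounds, the earlier single-place step concerned the removal of a whole butylcarbonyl at the other ester, so this is the first direct reading of chain length at this ester, and across this pair the assay does not distinguish the two chains. No measured property in the series bears on this result, so the flat step stays a plain observation without an explanation.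

From the compounds shown here alone, two chain lengths cannot define a trend, so it remains open whether a longer chain, such as octanoyl, or a still shorter acetyl would also stay within the scatter. Going by these compounds, it also remains open whether a chain carrying an amine or a carboxylic acid would be tolerated at this ester.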